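The source may hold more compounds than are shown below. What is called first, only, known or untested is meant among the compounds shown, and "the series" means these compounds.

In a physicochemical assay (on this read-out lower numbers stand for stronger inhibition and higher numbers for weaker inhibition), compound 1 `O=c1[nH]nc(Cc2ccc(Cl)cc2)n1/N=C/c1ccc(O)c(O)c1` gives 0.026 ug/mL and compound 2 `COc1ccc(Cc2n[nH]c(=O)n2/N=C/c2ccc(O)c(O)c2)cc1` gives 0.05 ug/mL, so the two sit level within the scatter. Compound 3 `O=c1[nH]nc(-c2ccccc2)n1/N=C/c1ccc(O)c(O)c1` has not yet been measured. It carries phenyl in place of 4-chlorobenzyl on an aromatic carbon. Among the measured compounds shown here, the one measured step, a 1.9-fold higher number from compound 1 to compound 2 (0.28 log units; within the scatter), only swaps methoxy for chloro, so it offers little guidance, and no measured compound lacks the benzyl group. A modestly higher number is expected, though with real uncertainty, an estimated step of a 2.3-fold higher number from compound 1 to compound 3 (0.36 log units; beyond the scatter). Compound 3 is estimated at 0.06 ug/mL, with an expected range from 0.015 ug/mL to 0.3 ug/mL.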

Compound 3, half-maximal inhibitory concentration: 0.5 ug/mL
The estimate for compound 3 lay 8.3-fold (0.92 log units) below the measured number; measured number above the stated range.
By their numbers in this assay, from the lowest: compounds 1 and 2 (each within the scatter of the next); then compound 3.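

In this assay replacing 4-chlorobenzyl with phenyl gives a 19-fold higher number from compound 1 to compound 3 (1.28 log units; beyond the scatter) and so much weaker inhibition, whereas swapping chloro for methoxy stayed within the scatter. This position on the five-membered ring therefore tolerates a change on the benzyl group's ring better than loss of the whole 4-chlorobenzyl group. No measurement here explains the loss.

The compounds shown do not separate the part played by the chlorine from that of the carbon linking the two rings. Plain benzyl would separate them, and 2-phenylethyl, a longer chain, would show how linker length counts.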